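Shortening the Linker to a Direct Carboxyphenyl Ether

A few compounds are considered here, and "the series" means these few. Any claim that something is new, unique, unknown or untested is made for them only; others in the source may bear on it.

Measured compounds:
Compound 1 `Cc1c(OCCCCOCOc2ccc(C(=O)O)cc2)ccc(C(=O)CC2CCCC2)c1O` gives 228 nM in an assay on HEK293 cells for positive allosteric modulation of metabotropic glutamate receptor 2 (Rattus norvegicus), read by thallium flux, with a stated time of 2.5 min; on this read-out higher numbers stand for an effect only at larger amounts of compound and lower numbers for an effect already at smaller amounts.
Compound 2 `Cc1c(OCCCCOc2ccc(C(=O)C(C)C)c(O)c2C)cccc1C(=O)O` gives 149 nM in this assay.

Compound 1 carries the higher of the two numbers in this assay, but its distance from compound 2 lies within the scatter of repeated measurements, so the two values cannot be ordered. Within the data shown here, no pair of measured compounds differs in a single place, so no step within the measured set is available for comparison.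

Compound 3 `Cc1c(OCCCCOc2cccc(C(=O)O)c2)ccc(C(=O)CC2CCCC2)c1O` has not yet been measured. It differs from compound 1 by 3-carboxyphenyl in place of (4-carboxyphenoxy)methyl on an oxygen on a saturated carbon. Among the measured compounds shown here, since no measured step covers this kind of change, the expectation for compound 3 rests only on the closeness of compound 1 and compound 2, both of which present a carboxylic acid on an aryl ether at the end of the chain. Compound 3 is expected to stay in the same region, with a step of a 1.3-fold lower number from compound 1 to compound 3 (0.10 log units; within the scatter) that is estimated to be no larger than the scatter. The estimated value of compound 3 in this assay is 180 nM, with a range from 70 nM to 500 nM.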

Compound 3, half-maximal effective concentration: 451 nM
Compound 3: middle estimate off by 2.5-fold (0.40 log units), on the low side, and the stated range covers the measured number.
By their numbers in this assay, from the lowest: compounds 2, 1 and 3 (each within the scatter of the next, the first and the last beyond it).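

Among these compounds, this is the first step that changes only one place: on an oxygen on a saturated carbon, 3-carboxyphenyl replaces (4-carboxyphenoxy)methyl, giving a 2.0-fold higher number from compound 1 to compound 3 (0.30 log units; within the scatter) in this assay. The step does not separate the two compounds, so this position accepts the shorter aryl ether end group without a change that can be read beyond the usual variation between repeated measurements, and both end groups keep a carboxylic acid on an aromatic ring. No supporting measurement bears on why the two end groups fall so close together.

The change also alters two features at once, the connection to the aromatic ring and the ring position of the carboxylic acid, so the compounds shown cannot assign any part of the step to either feature; a 4-carboxyphenyl group on the same oxygen would separate them. They also leave open whether the carboxylic acid itself matters at this position, a question that a primary amide or a methyl ester in its place would address.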